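Aryl swap at the amide-type nitrogen: compound 2 to compound 3

The source may hold more compounds than are shown below. What is called first, only, known or untested is meant among the compounds shown, and "the series" means these compounds.

Compound 1 `COc1ccc(-c2ccc3c(c2)C(=O)C(=O)N3Cc2ccc(Cl)cc2)cc1` gives 250 nM in a functional assay on HepG2 cells (Homo sapiens) for antiproliferative activity, read by MTT assay, with a stated time of 48 h; a lower number here means a stronger inhibitor, a higher number a weaker inhibitor. Compound 2 `COc1ccc(-c2ccc3c(c2)C(=O)C(=O)N3Cc2cc(C)cc(C)c2)cc1` gives 410 nM in this assay. On the two numbers shown, compound 2 is separated from compound 1 only by a 1.6-fold higher number from compound 1 to compound 2 (0.21 log units; within the scatter), a step within the scatter, so the two compounds are not distinguished by this assay.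

Compound 3 `COc1ccc(-c2ccc3c(c2)C(=O)C(=O)N3Cc2ccc3ccccc3c2)cc1` differs from compound 2 by naphthalen-2-yl in place of 3,5-dimethylphenyl on a saturated chain carbon bound to an amide-type nitrogen in a ring. Among the measured compounds shown here, the only measured step touching this position is a 1.6-fold higher number from compound 1 to compound 2 (0.21 log units; within the scatter), and it stayed within the scatter when one aryl group replaced another there. For the measured compounds named here, no measured step with a naphthalen-2-yl at this position exists, so the expectation rests on that single comparison alone. The step of a 1.2-fold lower number from compound 2 to compound 3 (0.07 log units; within the scatter) is therefore expected to be small, not beyond the scatter in either direction. Compound 3 is estimated at 350 nM in this assay, with a range from 140 nM to 900 nM.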

Compound 3, half-maximal inhibitory concentration: 380 nM
Beside the measured number, compound 3's estimate is 1.1-fold (0.04 log units) below it; the range from low to high includes it.
By their numbers in this assay, from the lowest: compounds 1, 3 and 2 (each within the scatter of the next).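

Naphthalen-2-yl brings a second six-membered aromatic ring of carbon only to the saturated chain carbon bound to the amide-type nitrogen in the ring, and in this assay neither new comparison goes beyond the scatter (a 1.1-fold lower number from compound 2 to compound 3 (0.03 log units; within the scatter); a 1.5-fold higher number from compound 1 to compound 3 (0.18 log units; within the scatter)). The earlier pair covered only single-ring aryl groups, whereas this result shows that the rise from 8 to 10 heavy atoms, with the added ring, also leaves compounds 1, 2 and 3 undistinguished in this assay. No independent measurement is available to explain this flat result.

As far as these compounds go, it remains open whether this tolerance extends beyond carbon-only aryl groups, for example to a pyridine ring, or to an aryl group carrying an amine or a carboxylic acid. A longer chain between the amide-type nitrogen and the aryl group is also untested by the compounds shown here.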